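The compounds below may be only part of what the source reports. "The series", "measured", "known", "first", "only" and "open" are said of these compounds alone.

In an ADME assay on MT4 cells (Homo sapiens) for cytotoxicity, read by MTT assay, with a stated time of 4 days (on this read-out lower numbers stand for higher toxicity in this test and higher numbers for lower toxicity in this test), two compounds with the shared core have been measured. Compound 1 `O=C(c1ccccc1)c1cc(Cl)ccc1OCCn1ccc(=O)[nH]c1=O` gives > 337000 nM, which is a limit of the assay and not a number. Within the data shown here, compound 2 `Cc1cc(C)cc(C(=O)c2cc(C)ccc2OCCn2ccc(=O)[nH]c2=O)c1` gives 179000 nM, the only actual number available in this assay. Compound 3 `Cc1cc(C)cc(C(=O)c2cc(Cl)ccc2OCCn2ccc(=O)[nH]c2=O)c1` differs from compound 2 in one place: chloro in place of methyl on an aromatic carbon. This is chloro in place of methyl on an aromatic carbon, meta to a large group and para to a large group. Compound 3 thereby shares its chloro with compound 1. Among the measured compounds shown here, no measured step covers this change, so the expectation starts from compound 2 at 179000 nM. The expected step of a 1.2-fold higher number from compound 2 to compound 3 (0.09 log units; within the scatter) is small, leaning towards lower toxicity in the test, and may not exceed the scatter. For compound 3 the estimated value is 220000 nM, with an expected range from 120000 nM to 380000 nM.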

Compound 3, half-maximal cytotoxic concentration in the MT4 assay: > 313000 nM
Compound 3 gave a limit, no number; the forecaster's own chance of this, stated with the estimate: 35%; middle value at least 1.4-fold (0.15 log units) away from the limit.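

In the MT4 assay, chloro in place of methyl on this aromatic carbon gives an at least 1.7-fold higher number from compound 2 to compound 3 (0.24 log units; that floor lies within the scatter), so the change shows no sign of raising toxicity in the test, although that floor alone does not separate the two compounds. Compound 3 gives a limit of the assay and not a number: the limit of > 313000 nM in the MT4 assay, at which 1 of the 3 values shown sits. In a physicochemical assay for solubility (on this read-out higher numbers stand for higher solubility and lower numbers for lower solubility), compound 2 gives 58500 nM and compound 3 gives 16600 nM. Among these compounds, in the physicochemical assay, the same change at this position, which the earlier compounds could not show, comes with a real loss of solubility: the measured solubility of compound 2, 58500 nM, and of compound 3, 16600 nM, a 3.5-fold lower number (0.55 log units; beyond the scatter).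

Compound 1 and compound 3 both rest on limits, so the step between them cannot be read. Going by these compounds, whether an amine or a methoxy group on this same carbon would keep toxicity in the test as low without that loss of solubility remains open.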